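Dithiol anilide series: chloro on the pyridin-2-yl core

The source may report more compounds than this note shows. Statements on the series, on what has been measured and on what is new or still open speak of the compounds shown alone.

Measured so far:
Compound 1 `O=C(CCCCC(S)CCS)Nc1ccccc1` gives 5.5% in a functional assay on NCI-H460 cells (Homo sapiens) for inhibition, read by MTT assay, with a stated time of 24 h, tested at 0.1 ug/mL; a higher number here means more inhibition of growth at the concentration tested, a lower number less inhibition of growth.
Compound 2 `O=C(CCCCC(S)CCS)Nc1ccccc1Cl` gives 6.36% in this assay.
Compound 3 `O=C(CCCCC(S)CCS)Nc1ccccn1` gives 5.01% in this assay.

All three numbers lie within the scatter of one another. The change chloro in place of hydrogen on an aromatic carbon occurs once among the measured compounds, where it gave a number 0.9 percentage points higher from compound 1 to compound 2 (within the scatter). Compound 4 `O=C(CCCCC(S)CCS)Nc1ccc(Cl)cn1` carries the same kind of change on the core of compound 3; the two cores differ by pyridin-2-yl in place of phenyl on an amide-type nitrogen, a step of a number 0.5 percentage points lower from compound 1 to compound 3 (within the scatter). The places are not the same: in compound 2 the chloro sits on a six-membered aromatic ring of carbon only, ortho to a large group, whereas in compound 4 it sits on a six-membered aromatic ring with 1 nitrogen, two atoms from the ring nitrogen, para to a large group; the change is chloro in place of hydrogen on an aromatic carbon. The expected step is a number 1 percentage points higher from compound 3 to compound 4 (within the scatter), because a number 0.9 percentage points higher from compound 1 to compound 2 (within the scatter) stayed within the scatter. Compound 4 is estimated at 6%, between 1% and 12%.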

Compound 4, percent growth inhibition at one concentration: "not active" (no number reported)
Nothing numeric was reported for compound 4; no gap can be computed for the estimate.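

For the compounds shown here, compound 4 is reported as "not active" in this assay, with no number given, and no step from compound 3 to compound 4 can be read. No available evidence bears on this result. The compounds shown leave open how far chloro at this place shifts growth inhibition on the core of compound 3.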